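The source may hold more compounds than are shown below. What is called first, only, known or untested is meant among the compounds shown, and "the series" means these compounds.

The set comprises three measured compounds and one still to be measured in a functional assay, with a stated time of 10 min; on this read-out lower numbers stand for stronger inhibition and higher numbers for weaker inhibition. Compound 1 `CSc1nc(-c2cccs2)c(C#N)c(=O)n1C` gives 72 ug/mL, compound 2 `Cn1c(NN)nc(-c2cccs2)c(C#N)c1=O` gives 53 ug/mL, and compound 3 `Cn1c(NN)nc(-c2cccc(O)c2O)c(C#N)c1=O` gives 29 ug/mL. Compound 2 and compound 1 differ in one place, (methylsulfanyl in place of aminoamino on an aromatic carbon), and that change produced the step of a 1.4-fold higher number from compound 2 to compound 1 (0.13 log units; within the scatter). The difference between the cores of compound 2 and compound 3 is not broken down here. Compound 4 `CSc1nc(-c2cccc(O)c2O)c(C#N)c(=O)n1C` follows from compound 3 by methylsulfanyl in place of aminoamino on an aromatic carbon, the same kind of change as before; the surroundings differ only in that the place in compound 2 is meta to a thiophen-2-yl group (5 heavy atoms), whereas in compound 3 it is meta to a group of 8 heavy atoms. The expected step, which rests on the earlier 1.4-fold higher number from compound 2 to compound 1 (0.13 log units; within the scatter), is a 1.4-fold higher number from compound 3 to compound 4 (0.14 log units; within the scatter). Compound 4 is therefore estimated at 40 ug/mL in this assay, most likely between 20 ug/mL and 80 ug/mL.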

Compound 4, half-maximal inhibitory concentration: 37 ug/mL
For compound 4 the middle estimate is 1.1-fold (0.03 log units) above the measured one; low and high end bracket the measured number.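

In this assay the exchange of aminoamino for methylsulfanyl gave a 1.3-fold higher number from compound 3 to compound 4 (0.11 log units; within the scatter), so on this core too the change stayed small. The step carried from one core to the other without a discernible difference: the same change on two cores in this assay, a 1.4-fold higher number (0.13 log units; within the scatter) from compound 2 to compound 1 and a 1.3-fold higher number (0.11 log units; within the scatter) from compound 3 to compound 4, 1.1-fold (0.03 log units) apart, within the scatter of two such steps This shows that the change behaved alike on these two cores; it does not show that the exchange has any real effect on inhibition, as both steps lie within the scatter, and two cores make no rule for the whole series.

The compounds shown leave open whether an amine, a morpholine or a longer alkylsulfanyl chain at this place would move the number beyond the scatter. Also open, on these data alone, is how the change behaves on a core carrying an unsubstituted phenyl group.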